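Acetoxy for the Amide: What Compound 4 Might Show

The source may report more compounds than this note shows. Statements on the series, on what has been measured and on what is new or still open speak of the compounds shown alone.

Measured so far:
Compound 1, `COc1ccc(-c2c(C)oc3c(N4CC[C@@H](NC(C)=O)C4)cc(C)nc23)cc1OC`, this assay: > 95%
Compound 2, `CSc1ccc(-c2c(C)nc3c(N4CC[C@@H](NC(C)=O)C4)cc(C)nn23)cc1`, this assay: > 95%
Compound 3, `COc1ccc(-c2c(C)nc3c(N4CC[C@@H](NC(=O)C(F)(F)F)C4)cc(C)nn23)cc1OC`, this assay: > 95%

Three compounds have been run in an ADME assay on microsomes from liver (Homo sapiens) for metabolic stability, read by LC-MS, with NADPH named in the record, with a stated time of 60 min, tested at 1 uM, in the absence of a further agent (on this read-out higher numbers stand for a more stable compound and lower numbers for a less stable compound), and none of them has returned a plain number. Compound 1 gives > 95%, which is a limit of the assay rather than a number. Compound 2 gives > 95%, likewise a limit. Compound 3 gives > 95%, again a limit. Within the data shown here, compound 3 therefore stands at the limit of > 95% in this assay, at which 3 of the 3 values shown sit, and no pair among the measured compounds differs in a single place, so the measurements give no step from which the effect of a change on the saturated ring carbon could be read.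

Compound 4 `COc1ccc(-c2c(C)nc3c(N4CC[C@@H](OC(C)=O)C4)cc(C)nn23)cc1OC` is the next to be measured in this assay. It differs from compound 3 in one place: acetoxy in place of ((trifluoromethyl)carbonyl)amino on a saturated ring carbon.

Among the measured compounds shown here, with no measured step to lean on, the step of a number at least 7 percentage points lower from compound 3 to compound 4 (that floor lies within the scatter) is expected to be small and downward, quite possibly within the scatter. Compound 4 is accordingly expected to give 88%, with a range from 65% to 95%.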

Compound 4, percent of the compound remaining: > 95%
Compound 4: a limit, no number; the forecaster's own chance of this, stated with the estimate: 50%; middle value at least 7 percentage points away from the limit.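

In this assay, among these compounds, compound 4 gives > 95%, a limit and not a number, and with compound 3 also at a limit, no step between compound 3 and compound 4 can be read. The compounds shown leave open how any structural change among them shifts the read-out: the limit of > 95% in this assay, at which 4 of the 4 values shown sit.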